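This account rests on a few compounds, and the source may have more. Where it says the series, first, only, none or still open, it means among the compounds named here.

Measured compounds:
compound 1, `COc1ccc(C(N)=O)cc1/C=C/c1cccc(Cl)c1`, 24000 nM
compound 2, `COc1ccc(C(N)=O)cc1/C=C/c1ccccc1Cl`, 23000 nM
compound 3, `COc1ccc(C(N)=O)cc1/C=C/c1ccc(Cl)cc1Cl`, 2600 nM

All three numbers come from a functional assay on HUVEC cells (Homo sapiens) for inhibition, with a stated time of 4 days; a higher number here means a weaker inhibitor, a lower number a stronger inhibitor. Compound 1 and compound 2 are built from the same atoms joined differently; the difference between the two cores is not broken down here, and their values lie within the scatter of each other. Compound 3 differs from compound 2 by chloro in place of hydrogen on an aromatic carbon; this change gave an 8.8-fold lower number from compound 2 to compound 3 (0.95 log units; beyond the scatter).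

The unmeasured compound 4, `COc1ccc(C(N)=O)cc1/C=C/c1ccc(Cl)c(Cl)c1`, differs from compound 1 by chloro in place of hydrogen on an aromatic carbon. For the measured compounds named here, this is the same kind of change as the one from compound 2 to compound 3, not the same: in compound 3 the entering chloro sits meta to a chloro group, in compound 4 it sits ortho to a chloro group; in both it is para to a large group.

For compound 4 in this assay a step of about a 6.9-fold lower number from compound 1 to compound 4 (0.84 log units; beyond the scatter) is expected, resting on the step of an 8.8-fold lower number from compound 2 to compound 3 (0.95 log units; beyond the scatter) and on compound 1 giving 24000 nM. The different surroundings of the place leave the size of the step uncertain. Compound 4 is estimated at 3500 nM, between 1200 nM and 10000 nM.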

Compound 4, half-maximal inhibitory concentration: 560 nM
Compound 4: middle estimate off by 6.3-fold (0.80 log units), on the high side, and the stated range ends above it.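

In this assay, chloro in place of hydrogen on an aromatic carbon gave a 43-fold lower number from compound 1 to compound 4 (1.63 log units; beyond the scatter), so the number fell on both cores, but the two steps differ in size: the same change on two cores in this assay, an 8.8-fold lower number (0.95 log units; beyond the scatter) from compound 2 to compound 3 and a 43-fold lower number (1.63 log units; beyond the scatter) from compound 1 to compound 4, 4.8-fold (0.69 log units) apart, beyond the scatter of two such steps

Across these two pairs the direction of the change carried from one core to the other, while its size did not, so a step measured on one core is a poor guide to the size of the step on another. For the compounds shown here, with only two pairs, this does not show whether the gap goes with the entering chloro sitting ortho to a chloro group in compound 4, nor does it give a typical size for the change.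

The compounds shown leave open whether a bromo or a methyl group at the same place would follow the chloro result. They also leave open whether the pattern would hold with a carboxylic acid in place of the amide.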